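Trimming the Aryl Group from a Fatty Acid Receptor Agonist

The source may report more compounds than this note shows. Statements on the series, on what has been measured and on what is new or still open speak of the compounds shown alone.

Compound 1 `Cc1ccccc1-c1cc(C#Cc2ccc(CCC(=O)O)cc2)ccn1` is one of three measured compounds that share a core. In an in vitro functional assay on 1321-N1 cells for agonist activity at Free fatty acid receptor 1 (Homo sapiens), read by fluorescence, spectrophotometry and calcium flux (on this read-out higher numbers stand for larger maximal responses and lower numbers for smaller maximal responses), compound 1 gives 92%, the lowest of the three numbers. Compound 3 `O=C(O)C1CC1c1ccc(C#Cc2cc(Cl)nc(Cl)c2)cc1` gives 96%, a result that sits within the scatter of the result for compound 1. Compound 2 `Cc1cc(C#Cc2ccc(CCC(=O)O)cc2)nc(Cl)n1` gives 110%, which lies beyond the scatter above compound 1. No pair among these three differs in a single place, so no step between measured compounds can be read from them.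

Compound 4 `O=C(O)CCc1ccc(C#Cc2ccncc2)cc1` differs from compound 1 in one place: hydrogen in place of 2-methylphenyl on an aromatic carbon. The 2-methylphenyl group leaves and a hydrogen enters on an aromatic carbon. Among the compounds with values here, the measured set contains no pair that shows what such a removal does, so the expectation rests on the size of the group that leaves alone. The step expected in this assay is a number 32 percentage points lower from compound 1 to compound 4 (beyond the scatter), a downward move beyond the scatter. Compound 4 is accordingly expected to reach 60%, with a range from 20% to 100%.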

Compound 4, largest response reached (reported as efficacy), in percent of the reference or control that the assay uses: 100%
The estimate for compound 4 lay 40 percentage points below the measured number; the measured number falls inside the stated range.
By their numbers in this assay, from the lowest: compounds 1, 3, 4 and 2 (each within the scatter of the next, the first and the last beyond it).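

Taking the 2-methylphenyl group off this aromatic carbon, next to the ring nitrogen, gives a number 8 percentage points higher from compound 1 to compound 4 (within the scatter) in this assay, so the two compounds cannot be told apart on this read-out. Within the data shown here, compound 4 thus shows that a maximal response of this size does not depend on the 2-methylphenyl group at this position, which the earlier compounds, with no single-place pair among them, could not show. Nothing measured here gives a reason for this result.

What the compounds shown leave open is whether the position accepts other groups, such as a methoxy group or an amine, with the same outcome. They also leave open whether the removal changes anything other than the largest response reached, such as the concentration needed to reach it.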